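Removing a Methyl from the Most Potent Urea

The compounds below may be only part of what the source reports. "The series", "measured", "known", "first", "only" and "open" are said of these compounds alone.

Of the compounds shown here, three have been tested in a functional assay on HOP-92 cells (Homo sapiens) for inhibition, read by sulforhodamine B assay, with a stated time of 48 h (on this read-out higher numbers stand for weaker inhibition of growth and lower numbers for stronger inhibition of growth), so far. Compound 1 `O=C(Nc1cccc(-n2cc(-c3ccncc3)c(-c3ccc(Cl)c(O)c3)n2)c1)Nc1cccc(C(F)(F)F)c1` gives 509 nM in this assay. Within the data shown here, compound 3 `COc1cc(-c2nn(-c3cccc(NC(=O)Nc4cccc(C(F)(F)F)c4)c3)cc2-c2ccncc2)ccc1Cl` gives 557 nM in this assay, and the only change between them, methyl in place of hydrogen on an oxygen on an aromatic ring, leaves the read-out essentially unmoved: a 1.1-fold higher number from compound 1 to compound 3 (0.04 log units; within the scatter). Compound 2 `COc1cc(-c2nn(-c3cccc(NC(=O)Nc4cc(C(F)(F)F)cc(C(F)(F)F)c4)c3)cc2-c2ccncc2)ccc1Cl` gives 144 nM in this assay, the lowest of the three numbers; adding a second trifluoromethyl group on the aromatic carbon is what separates it from compound 3, and that step is clearer: a 3.9-fold higher number from compound 2 to compound 3 (0.59 log units; beyond the scatter). Compound 2 is therefore the strongest growth inhibitor measured here.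

Compound 4 `O=C(Nc1cccc(-n2cc(-c3ccncc3)c(-c3ccc(Cl)c(O)c3)n2)c1)Nc1cc(C(F)(F)F)cc(C(F)(F)F)c1` keeps both trifluoromethyl groups of compound 2 and differs from it only in hydrogen in place of methyl on an oxygen on an aromatic ring. Among the measured compounds shown here, the one measured step that bears on this change runs the opposite way, from hydroxy to methoxy, and it stayed within the scatter. The same change applied to compound 2 is therefore expected to leave this assay essentially unchanged, so the estimated step is a 1.0-fold higher number from compound 2 to compound 4 (0.02 log units; within the scatter). Compound 4 is estimated to give 150 nM in this assay, with a range from 70 nM to 320 nM.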

Compound 4, concentration for 50% growth inhibition: 344 nM
Beside the measured number, compound 4's estimate is 2.3-fold (0.36 log units) below it; the measured number lies above the stated range.
By their numbers in this assay, from the lowest: compound 2; then compounds 4, 1 and 3 (each within the scatter of the next).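

In this assay, the step from methoxy to hydroxy is no longer silent when the urea carries two trifluoromethyl groups: a 2.4-fold higher number from compound 2 to compound 4 (0.38 log units; beyond the scatter). On the core with one trifluoromethyl group the same change had left the number in place, but the two readings cannot be told apart, so a real dependence on the rest of the molecule is not established: the same change on two cores in this assay, a 1.1-fold higher number (0.04 log units; within the scatter) from compound 1 to compound 3 and a 2.4-fold lower number (0.38 log units; beyond the scatter) from compound 4 to compound 2, 2.6-fold (0.42 log units) apart, within the scatter of two such steps. The second trifluoromethyl group, which gave a clear step on the methoxy compounds, gives only a 1.5-fold lower number from compound 1 to compound 4 (0.17 log units; within the scatter) on the hydroxy compounds, yet this pair of steps also cannot be separated: the same change on two cores in this assay, a 3.9-fold higher number (0.59 log units; beyond the scatter) from compound 2 to compound 3 and a 1.5-fold higher number (0.17 log units; within the scatter) from compound 4 to compound 1, 2.6-fold (0.42 log units) apart, within the scatter of two such steps.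

Among these compounds, with only two pairs for each change, it remains open whether the benefit of the second trifluoromethyl group truly depends on the methoxy group, or whether the methoxy and trifluoromethyl steps simply add up within the scatter. The compounds shown also leave open how a longer chain on this oxygen, such as ethoxy, or an amine in place of the methoxy would compare with the methoxy and hydroxy groups on either core.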